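A Butyl Group on the Chain of Compound 1

The source may report more compounds than this note shows. Statements on the series, on what has been measured and on what is new or still open speak of the compounds shown alone.

Compound 1 `CCC(CCO)n1cnc2c(Cl)nc(F)nc21`: 18900 nM
Compound 2 `CCC(CCO)n1cnc2c(Cl)ncnc21`: > 50000 nM (a limit)
Compound 3 `CCCCC(CCO)n1cnc2c(Cl)nc(Cl)nc21`: 15500 nM

In a functional assay on HCT-116 cells (Homo sapiens) for antiproliferative activity, read by MTT assay, with a stated time of 48 h (a higher number here means a weaker inhibitor, a lower number a stronger inhibitor), compound 1 gives 18900 nM, and compound 3 gives 15500 nM, a value within the usual scatter of it. Compound 2 gives > 50000 nM, which is a limit of the assay.

Compound 4 `CCCCCCC(CCO)n1cnc2c(Cl)nc(F)nc21` is compound 1 with one change: butyl in place of hydrogen on a saturated chain carbon, three bonds along the chain from an aromatic nitrogen. Among the compounds with values here, the only measured step, an at least 2.6-fold higher number from compound 1 to compound 2 (0.42 log units; beyond the scatter), lies beyond the scatter, but it replaces fluoro with hydrogen on an aromatic carbon, not on the chain, so it offers no direct guide. Within the data shown here, with compound 3 at 15500 nM as the only other number, no step beyond the scatter is expected. The estimated step is a 1.4-fold lower number from compound 1 to compound 4 (0.13 log units; within the scatter). For compound 4 the estimate is 14000 nM, with an expected range of 5000 nM to 40000 nM.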

Compound 4, half-maximal inhibitory concentration: 9960 nM
Beside the measured number, compound 4's estimate is 1.4-fold (0.15 log units) above it; measured number inside the range.
By their numbers in this assay, from the lowest: compounds 4, 3 and 1 (each within the scatter of the next). At a limit, above all of these: compound 2.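

In this assay, butyl in place of hydrogen on the saturated chain carbon, three bonds along the chain from an aromatic nitrogen, gives a 1.9-fold lower number from compound 1 to compound 4 (0.28 log units; within the scatter). Within the data shown here, this is the first direct reading of a change at this chain position, and it shows that adding butyl there costs no activity and produces no gain that can be told from the scatter. No measurement shown here accounts for the step. On these data alone, whether a longer chain, an amine or a carboxylic acid at this position would move the number beyond the scatter remains open.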